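Replacing the diaryl ether of compound 2 with an amide

The source may hold more compounds than are shown below. What is called first, only, known or untested is meant among the compounds shown, and "the series" means these compounds.

Measured compounds:
compound 1 `O=C(O)c1ccc2noc(-c3ccc(Oc4ccccc4)cc3)c2c1`, 550 nM
compound 2 `O=C(O)c1ccc2noc(-c3ccc(Oc4ncc(Cl)cc4Cl)cc3)c2c1`, 2250 nM

In an assay for inhibition of inositol hexakisphosphate kinase 3 (Homo sapiens), read by colorimetric assay, coupled enzyme assay and malachite green, with a stated time of 120 min, in the presence of a further agent that is not named here (a lower number here means a stronger inhibitor, a higher number a weaker inhibitor), compound 2 gives 2250 nM, the higher of the two numbers; compound 1 sits below it by a 4.1-fold higher number from compound 1 to compound 2 (0.61 log units; beyond the scatter). Compound 3 `CC(C)NC(=O)c1ccc(-c2onc3ccc(C(=O)O)cc23)cc1` differs from compound 2 by isopropylcarbamoyl in place of (3,5-dichloropyridin-2-yl)oxy on an aromatic carbon. Within the data shown here, the only measured step exchanges one aryl group for another on the ether oxygen and so bears only loosely on removing the ether altogether. Among the measured compounds shown here, with no closer precedent, compound 3 is expected to land near the middle of the two measured numbers, a step of a 2.3-fold lower number from compound 2 to compound 3 (0.35 log units; beyond the scatter). The estimate for compound 3 is 1000 nM, within 250 nM to 4000 nM.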

Compound 3, half-maximal inhibitory concentration: 340 nM
Estimate against measurement, compound 3: 2.9-fold (0.47 log units) above; the range from low to high includes it.
By their numbers in this assay, from the lowest: compounds 3 and 1 (each within the scatter of the next); then compound 2.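

In this assay, an aryl ether is not required on this aromatic carbon: isopropylcarbamoyl, which has no ring, gives a 6.6-fold lower number from compound 2 to compound 3 (0.82 log units; beyond the scatter). Set against the plain phenoxy group, it gives a 1.6-fold lower number from compound 1 to compound 3 (0.21 log units; within the scatter), so this amide serves as well as phenoxy, whereas the earlier compounds compared only two aryl ethers. Nothing available explains either step. Still open, from the compounds shown here alone, is whether the amide hydrogen matters, which a dimethylamide would address, and whether cyclopropyl or tert-butyl on the amide nitrogen would serve as well as isopropyl.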